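The compounds below may be only part of what the source reports. "The series", "measured", "known", "first", "only" and "open" are said of these compounds alone.

Compounds measured in an assay for binding affinity to adenosine receptor A1 (Bos taurus); on this read-out lower numbers stand for stronger inhibition and higher numbers for weaker inhibition:
- compound 1, `Cc1cc(O)cc(C)c1-c1nc2c(=O)n(C)c(=O)n(C)c2[nH]1`: 30 nM
- compound 2, `Cn1c(=O)c2nc(-c3ccc(I)cc3)[nH]c2n(C)c1=O`: 1.3 nM
- compound 3, `C=CCn1c(=O)c2[nH]c(-c3ccc(Cl)cc3N)nc2n(C)c1=O`: 2 nM

All three compounds share the same core and differ in the aromatic ring attached to it and in the small groups on that ring. In this assay compound 2 gives the lowest of the three numbers. The value of compound 3 lies so close to it that the two cannot be told apart, the gap being within the usual scatter of the measurement. The value of compound 1, by contrast, lies well beyond the scatter and marks clearly weaker binding.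

Compound 4, `Cn1c(=O)c2nc(-c3ccc(Br)cc3)[nH]c2n(C)c1=O`, has not been measured in this assay. It differs from compound 2 in one place: bromo in place of iodo on an aromatic carbon. Among the compounds with values here, no two measured compounds differ from each other in just this way, so there is no measured step to lean on. The change swaps one halogen for a related one, and the expectation is that the step from compound 2 to compound 4 in this assay is small, a 1.5-fold higher number from compound 2 to compound 4 (0.19 log units; within the scatter), in either direction or none beyond the scatter. For compound 4 the estimated value in this assay is 2 nM, with a likely range from 0.7 nM to 6 nM.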

Compound 4, half-maximal inhibitory concentration: 0.75 nM
For compound 4 the middle estimate is 2.7-fold (0.43 log units) above the measured one, and the stated range covers the measured number.
By their numbers in this assay, from the lowest: compounds 4, 2 and 3 (each within the scatter of the next, the first and the last beyond it); then compound 1.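

In this assay, swapping one halogen for another on this aromatic carbon, para to a large group, gives a 1.7-fold lower number from compound 2 to compound 4 (0.24 log units; within the scatter) and so leaves the number within the scatter. Within the data shown here, at this position, then, bromo and iodo cannot be told apart, something the earlier compounds could not show, since no two of them differed in just one place. No measurement of any property of these two groups is at hand to bear on this result.

Going by these compounds, whether this carbon accepts other groups equally well stays open, for a fluoro, a methoxy group or a carboxylic acid would each test it in a different way. Compound 1 and compound 3 differ from compound 2 in more than one place, so their values cannot settle what a single group does here.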